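A few compounds are considered here, and "the series" means these few. Any claim that something is new, unique, unknown or untested is made for them only; others in the source may bear on it.

Three compounds have been measured in a functional assay on HEK293 cells for antagonist activity at metabotropic glutamate receptor 5 (Rattus norvegicus), read by calcium flux; a lower number here means a stronger inhibitor, a higher number a weaker inhibitor:

Compound 1 `Cc1nc(C#Cc2cc(C#N)cc([N+](=O)[O-])c2)cs1` gives 2.63 nM
Compound 2 `Cc1nc(C#Cc2cc(Br)cc([N+](=O)[O-])c2)cs1` gives 0.73 nM
Compound 3 `Cc1nc(C#Cc2cc(Br)cc(Br)c2)cs1` gives 1.45 nM

Compound 2 gives the lowest number of the three. Against compound 3 the gap is small: a 2.0-fold higher number from compound 2 to compound 3 (0.30 log units; within the scatter), which is within the scatter, so the two cannot be ranked. Against compound 1 the gap is clearer: a 3.6-fold lower number from compound 1 to compound 2 (0.56 log units; beyond the scatter), beyond the scatter.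

The next compound, compound 4 `O=[N+]([O-])c1cc(Br)cc(C#Cc2ccccn2)c1`, keeps the aromatic ring of compound 2 with its nitro and bromo groups untouched and changes the other end of the molecule: pyridin-2-yl in place of 2-methyl-1,3-thiazol-4-yl on a triple-bonded carbon.

Neither measured step bears on this change. Among the compounds with values here, both steps swap groups on the benzene-type ring, and none touches the ring attached to the triple bond, so there is no measured precedent for exchanging a thiazole for a pyridine here. In the absence of such evidence, compound 4 is expected to stay near compound 2, with a step of a 2.1-fold higher number from compound 2 to compound 4 (0.31 log units; beyond the scatter) that is not expected to exceed the scatter, though the uncertainty is wide. The estimate for compound 4 in this assay is 1.5 nM, with a range from 0.3 nM to 8 nM.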

Compound 4, half-maximal inhibitory concentration: 0.39 nM
Compound 4: the middle estimate sits 3.8-fold (0.59 log units) above what was measured, within the range that was stated.
By their numbers in this assay, from the lowest: compounds 4, 2, 3 and 1 (each within the scatter of the next, the first and the last beyond it).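

Within the data shown here, until now only the groups on the other ring had varied; this pair is the first look at the ring on the triple-bonded carbon. In this assay, pyridin-2-yl in place of 2-methyl-1,3-thiazol-4-yl gives a 1.9-fold lower number from compound 2 to compound 4 (0.27 log units; within the scatter), so the two compounds cannot be ranked, and in this pair a low number does not depend on the thiazole, with its sulfur and methyl group. Nothing measured here explains why these two different rings give such similar numbers.

Still open, going by these compounds, is whether a plain phenyl ring, with no ring nitrogen at all, or a saturated ring such as piperidine would serve on that carbon as well. It is also unknown whether pyridin-2-yl would behave the same way with the cyano and nitro pair of compound 1 or the two bromo groups of compound 3.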